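Homologating the Sulfonamide Substituent in a Fused Imidazole Series

The compounds below may be only part of what the source reports. "The series", "measured", "known", "first", "only" and "open" are said of these compounds alone.

In an assay on cells for inhibition of cytochrome P450 11B1, mitochondrial (Homo sapiens) (on this read-out lower numbers stand for stronger inhibition and higher numbers for weaker inhibition), three compounds of a shared core have been measured. Compound 1 `C[C@@H](c1ccc(Cl)cc1)N1Cc2cncn2C(CC2(C)COC2)S1(=O)=O` gives 340 nM, compound 3 `COC(C)(C)CC1n2cncc2CN([C@@H](C)c2ccc(Cl)cc2)S1(=O)=O` gives 20.6 nM, and compound 2 `CC(C)CC1n2cncc2CN(C2CC2)S1(=O)=O` gives 930 nM, the highest number of the three, beyond the scatter from both others. Among the measured compounds shown here, the only one-place step among them, a 17-fold lower number from compound 1 to compound 3 (1.22 log units; beyond the scatter), concerns the chain on the saturated ring carbon and not the sulfonamide nitrogen.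

Compound 4 `CC(C)CC1n2cncc2CN(CC2CC2)S1(=O)=O` differs from compound 2 in one place: cyclopropylmethyl in place of cyclopropyl on a sulfonamide nitrogen in a ring. For the measured compounds named here, no measured step touches this position. Compounds 1 and 3 carry a different, larger group on the same nitrogen and give lower numbers than compound 2, but they also differ from compound 2 in the chain on the ring carbon, so their two values alone cannot be assigned to the nitrogen substituent.

Adding one carbon to the cyclopropyl is a small change, and the step from compound 2 to compound 4 in this assay is therefore expected to stay within the scatter, a 1.3-fold lower number from compound 2 to compound 4 (0.12 log units; within the scatter), leaning toward a lower number. Compound 4 is estimated at 700 nM, in the range 250 nM to 2000 nM.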

Compound 4, half-maximal inhibitory concentration: 122 nM
Compound 4: the middle estimate sits 5.7-fold (0.76 log units) above what was measured; the whole stated range lies above it.
By their numbers in this assay, from the lowest: compound 3; then compound 4; then compound 1; then compound 2.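

In this assay, the sulfonamide nitrogen proves to be a position that responds to a small change: with the isobutyl group held fixed, cyclopropylmethyl in place of cyclopropyl gives a 7.6-fold lower number from compound 2 to compound 4 (0.88 log units; beyond the scatter). Among the compounds shown here, this is the first measured step at this nitrogen, since the earlier step, a 17-fold lower number from compound 1 to compound 3 (1.22 log units; beyond the scatter), concerned only the chain on the saturated ring carbon. It shows that going from 3 to 4 heavy atoms, with the three-membered ring kept, is enough to move the number beyond the scatter, although no measurement at hand speaks to the origin of this step.

This single step cannot separate the effect of chain length from that of the cyclopropylmethyl group itself, a question that a 2-cyclopropylethyl group, a cyclobutylmethyl group or an open n-butyl chain on the same nitrogen could address. Going by these compounds, it also remains open whether the same change would give a step of similar size alongside the 1-methoxy-1-methylethyl-bearing chain of compound 3 rather than the isobutyl group.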